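The source may hold more compounds than are shown below. What is called first, only, known or untested is meant among the compounds shown, and "the series" means these compounds.

Compound 1 `CCN(CC)c1cc2[nH]c(C3CCCCC3)nc2cc1NC(=O)NCc1ccccc1` is set against compound 4 `CCCCNC(=O)Nc1cc2nc(C3CCCCC3)[nH]c2cc1N(CC)CC`, which has yet to be measured in an ADME assay on Vero cells (Chlorocebus sabaeus) for cytotoxicity, read by resazurin assay, with a stated time of 3 days; a higher number here means a weaker inhibitor, a lower number a stronger inhibitor. Compound 1 gives > 100 ug/mL, a limit of the assay rather than a number. Compound 2 `COCCOC(=O)Nc1cc2nc(C3CCCCC3)[nH]c2cc1N1CCCC1` likewise reaches only a limit, > 100 ug/mL. Compound 3 `O=C(NCc1ccccc1)Nc1cc2nc(C3CCCCC3)[nH]c2cc1N1CCCC1` also stops at a limit, > 100 ug/mL. All three thus sit together at the limit of > 100 ug/mL in this assay, at which 3 of the 3 values shown sit. The change from compound 1 to compound 4 is propyl in place of phenyl on a saturated chain carbon bound to an amide-type nitrogen. For the measured compounds named here, no measured step covers this swap: a step that the two limits leave unreadable from compound 1 to compound 3 and a step that the two limits leave unreadable from compound 2 to compound 3 are both unreadable, each running between limits. Compound 4 is therefore expected to stay at the limit as well, with an expected step that the limit leaves unreadable from compound 1 to compound 4 meaning no readable change. Compound 4 is estimated at 150 ug/mL, between 60 ug/mL and 400 ug/mL.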

Compound 4, half-maximal inhibitory concentration: > 100 ug/mL
Compound 4 ended at the assay's limit; the forecaster's own chance of this, stated with the estimate: 80%; the middle value is on the limit's open side.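

No new step can be read: compound 1 and compound 4 both stop at a limit in this assay, so propyl in place of phenyl shows no readable size. The compounds shown leave open where any of them would give an actual number, since all share one limit: the limit of > 100 ug/mL in this assay, at which 4 of the 4 values shown sit.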